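Disulfide variation on the thymidine core: cytotoxicity notes

The source may report more compounds than this note shows. Statements on the series, on what has been measured and on what is new or still open speak of the compounds shown alone.

Two compounds of the series carry a disulfide on the sugar. Compound 1 `CSS[C@H]1C[C@H](n2ccc(N)nc2=O)O[C@@H]1CO` bears a methyl on the outer sulfur and a different base; in a functional assay on MOLT-4 cells (Homo sapiens) for cytotoxicity (on this read-out higher numbers stand for weaker inhibition and lower numbers for stronger inhibition), compound 1 gives 149000 nM. Compound 2 `Cc1cn([C@H]2C[C@H](SSC(Cl)(Cl)Cl)[C@@H](CO)O2)c(=O)[nH]c1=O` bears a trichloromethyl on the outer sulfur; in this assay compound 2 gives 55000 nM. Compound 2 holds the lowest number of the two, and its gap to compound 1 lies beyond the scatter. The two compounds differ in more than one place, so no single step can be read from them.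

Compound 3 `Cc1cn([C@H]2C[C@H](SSc3ccccc3[N+](=O)[O-])[C@@H](CO)O2)c(=O)[nH]c1=O` differs from compound 2 in one place: 2-nitrophenyl in place of trichloromethyl on a sulfur. Among the measured compounds shown here, no measured pair shows this change, so its effect cannot be taken from the numbers in hand. For compound 3 the step from compound 2 is expected to be small, a 1.2-fold lower number from compound 2 to compound 3 (0.09 log units; within the scatter), and not clearly beyond the scatter in either direction. In this assay compound 3 is therefore estimated at 45000 nM, within a range from 12000 nM to 160000 nM.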

Compound 3, half-maximal inhibitory concentration: 31000 nM
For compound 3 the middle estimate is 1.5-fold (0.16 log units) above the measured one; the range from low to high includes it.
By their numbers in this assay, from the lowest: compounds 3 and 2 (each within the scatter of the next); then compound 1.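

Among the compounds shown here, exchanging trichloromethyl for 2-nitrophenyl on a sulfur whose other neighbour is sulfur gives a 1.8-fold lower number from compound 2 to compound 3 (0.25 log units; within the scatter) in this assay and provides the first reading at this position, since compounds 1 and 2 differ in more than one place. Within the two compounds of this pair, a group with no ring and a six-membered aromatic ring of carbon only on the outer sulfur cannot be told apart by this read-out, even though the entering group is larger and brings a nitro group with it. Nothing at hand accounts for the size of this step or ties it to any feature of either group.

Still open, on these data alone, is whether an amine, a carboxylic acid or a longer alkyl chain on the outer sulfur would carry the number beyond the scatter of the values seen with trichloromethyl and 2-nitrophenyl. As far as these compounds go, the separate contributions of the base and of the methyl on the outer sulfur in compound 1 also remain open, and the steps involving that compound cannot be read.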